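Notes on the step from compound 3 to compound 4

A few compounds are considered here, and "the series" means these few. Any claim that something is new, unique, unknown or untested is made for them only; others in the source may bear on it.

Measured in a functional assay on HT-29 cells (Homo sapiens) for inhibition, read by MTT assay, with a stated time of 120 h; a higher number here means a weaker inhibitor, a lower number a stronger inhibitor
Compound 1 `CC(NC(=O)C#Cc1ccc(NC(=O)Nc2cc(C(F)(F)F)ccc2Cl)cc1)c1ccccc1`: 3170 nM
Compound 2 `CC(NC(=O)/C=C/c1ccc(NC(=O)Nc2ccc(Cl)c(C(F)(F)F)c2)cc1)c1ccccc1`: 1060 nM
Compound 3 `CNC(=O)/C=C/c1ccc(NC(=O)Nc2ccc(Cl)c(C(F)(F)F)c2)cc1`: 11700 nM

Of the three measured compounds, compound 3 has the highest number, at 11700 nM, so it is the weakest inhibitor of the set. The next compound, compound 4 `O=C(CCc1ccc(NC(=O)Nc2ccc(Cl)c(C(F)(F)F)c2)cc1)NC1CCC1`, has not been measured. Its difference from compound 3 is 2-(cyclobutylcarbamoyl)ethyl in place of 2-(methylcarbamoyl)ethenyl on an aromatic carbon. In words, this is 2-(cyclobutylcarbamoyl)ethyl in place of 2-(methylcarbamoyl)ethenyl on an aromatic carbon.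

For the measured compounds named here, one measured step bears on this change: an 11-fold higher number from compound 2 to compound 3 (1.04 log units; beyond the scatter). That step is large and beyond the scatter, and it concerns the group on the amide nitrogen. Read in reverse, it pairs a group bigger than methyl with a lower number. Going by the values given here, no measured step isolates ethyl against ethenyl, so that part of the change is open. A move to a lower number in this assay is expected, smaller than the measured step. The expected step is a 2.3-fold lower number from compound 3 to compound 4 (0.37 log units; beyond the scatter). For compound 4 the estimate is 5000 nM, with an expected range from 1500 nM to 16000 nM.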

Compound 4, half-maximal inhibitory concentration: 21300 nM
Estimate against measurement, compound 4: 4.3-fold (0.63 log units) below; the measured number lies above the stated range.
By their numbers in this assay, from the lowest: compound 2; then compound 1; then compounds 3 and 4 (each within the scatter of the next).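

In this assay the exchange at this place, para to a large group, gives a 1.8-fold higher number from compound 3 to compound 4 (0.26 log units; within the scatter) and so leaves the number level, even with a larger side chain that carries a four-membered ring and has lost the ethenyl double bond. The earlier step on the amide nitrogen, an 11-fold higher number from compound 2 to compound 3 (1.04 log units; beyond the scatter), tied a group bigger than methyl to a lower number, but compound 4 goes against any general reading of that step, since its cyclobutyl amide on an ethyl chain brings no such gain. No measurement at hand explains this result.

The compounds shown leave open how the change divides between the cyclobutyl group and the loss of the ethenyl double bond, as the two parts may offset each other. Also open, on these data alone, is how an amine or a carboxylic acid on the chain at this place would read in this assay.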